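The source may hold more compounds than are shown below. What is called first, only, known or untested is meant among the compounds shown, and "the series" means these compounds.

Of the compounds shown here, three built on one shared core have been measured in a physicochemical assay for pharmacokinetics; a lower number here means that the compound disappears faster, a higher number that the compound lasts longer. Compound 1 `COc1ccc(CNC(=O)N2C(=O)c3ccccc3S2(=O)=O)cc1` gives 0.187 h. Compound 2 `O=C(NCc1ccc(C(F)(F)F)cc1)N1C(=O)c2ccccc2S1(=O)=O` gives 0.212 h. Compound 3 `O=C(NCc1ccccc1C(F)(F)F)N1C(=O)c2ccccc2S1(=O)=O` gives 0.187 h. Compounds 2 and 3 have the same atoms joined differently; the difference between the two cores is not broken down here.

From compound 2 to compound 1 the change is methoxy in place of trifluoromethyl on an aromatic carbon, and in this assay it made a 1.1-fold lower number from compound 2 to compound 1 (0.05 log units; within the scatter). Compound 3 and compound 1 stand level at the digits given, and all three numbers lie within the usual scatter of one another, so no order among them can be read from these data.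

The unmeasured compound 4 `COc1ccccc1CNC(=O)N1C(=O)c2ccccc2S1(=O)=O` differs from compound 3 by methoxy in place of trifluoromethyl on an aromatic carbon. Within the data shown here, this is the same kind of change as the one from compound 2 to compound 1, but not the same: in the earlier pair the group sits para to a large group, while here it sits ortho to a large group.

A step of about the same size is expected from compound 3 to compound 4, a 1.0-fold lower number from compound 3 to compound 4 (0.02 log units; within the scatter), because the earlier step of a 1.1-fold lower number from compound 2 to compound 1 (0.05 log units; within the scatter) stayed within the scatter. On that basis compound 4 is expected to give 0.18 h in this assay, with a likely range from 0.1 h to 0.32 h.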

Compound 4, half-life: 1.12 h
Compound 4: the middle estimate sits 6.2-fold (0.79 log units) below what was measured; measured number above the stated range.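

In this assay, methoxy in place of trifluoromethyl made almost no difference in one setting (a 1.1-fold lower number from compound 2 to compound 1 (0.05 log units; within the scatter)), yet on an aromatic carbon ortho to a large group the same swap gave a clear rise (a 6.0-fold higher number from compound 3 to compound 4 (0.78 log units; beyond the scatter)), so in this series the change did not carry over from one core to the other with the same size. Compound 4 also stands apart from its methoxy partner, with 2-methoxyphenyl in place of 4-methoxyphenyl giving a rise of the same size (a 6.0-fold higher number from compound 1 to compound 4 (0.78 log units; beyond the scatter)), which shows that in this pair the methoxy group alone does not set the number and that its place on the ring goes with the difference. These are single pairs, so they give no general rule for other cores, and nothing shown here explains why compound 4 lasts longer.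

The compounds shown leave open whether another group at that same place, such as a hydroxyl, an ethoxy group or an amine, would also give a higher number. They also leave open whether a longer chain leading to the 2-methoxyphenyl, or a different core carrying it, would keep the rise.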